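This account rests on a few compounds, and the source may have more. Where it says the series, first, only, none or still open, it means among the compounds named here.

Measured so far in a functional assay on MiaPaCa cells (Homo sapiens) for antiproliferative activity, read by sulforhodamine B assay, with a stated time of 48 h; on this read-out lower numbers stand for stronger inhibition of growth and higher numbers for weaker inhibition of growth:
- compound 1 `CCCCCCc1cn(CCCN2C(=O)COc3ccccc32)nn1`: 150 nM
- compound 2 `O=C1COc2ccccc2N1CCCn1cc(-c2cccnc2)nn1`: 8200 nM
- compound 3 `O=C1COc2ccccc2N1CCCn1cc(CO)nn1`: 1010 nM

Compound 3 holds the middle place among these numbers, set apart by a 6.7-fold higher number from compound 1 to compound 3 (0.83 log units; beyond the scatter) on one side and by an 8.1-fold lower number from compound 2 to compound 3 (0.91 log units; beyond the scatter) on the other. Compound 4 `CCCCc1cn(CCCN2C(=O)COc3ccccc32)nn1` has not yet been measured in this assay. It differs from compound 3 as follows: propyl in place of hydroxy on a saturated chain carbon bound to an aromatic carbon. Seen one bond further out, this is hydroxymethyl giving way to butyl.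

The closest guide is the modest 6.7-fold higher number from compound 1 to compound 3 (0.83 log units; beyond the scatter), since hexyl and butyl are both plain chains. Read in reverse, it points towards a lower number for compound 4. The large 55-fold higher number from compound 1 to compound 2 (1.74 log units; beyond the scatter) bears less directly, as it brings in pyridin-3-yl. Butyl is not hexyl, so a somewhat smaller step than the one back to compound 1 is expected. The expected step is a 3.4-fold lower number from compound 3 to compound 4 (0.53 log units; beyond the scatter). For compound 4 the estimated value is 300 nM, with an expected range of 120 nM to 750 nM.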

Compound 4, concentration for 50% growth inhibition: 2500 nM
Compound 4: middle estimate off by 8.3-fold (0.92 log units), on the low side, outside the stated range (above it).
By their numbers in this assay, from the lowest: compound 1; then compound 3; then compound 4; then compound 2.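

In this assay, the low number of compound 1 does not hold for plain chains in general: going from hexyl to butyl, which is hydrogen in place of ethyl on a saturated chain carbon, four bonds along the chain from an aromatic carbon, gives a 17-fold higher number from compound 1 to compound 4 (1.22 log units; beyond the scatter). Butyl also falls behind hydroxymethyl, with a 2.5-fold higher number from compound 3 to compound 4 (0.39 log units; beyond the scatter), so at this position chain length decides the result among the plain chains, and a plain chain does not beat hydroxymethyl as such, although butyl still improves on pyridin-3-yl, with a 3.3-fold lower number from compound 2 to compound 4 (0.52 log units; beyond the scatter). Nothing available explains why the two extra carbons of hexyl matter so much.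

The compounds shown leave open whether the number changes gradually from butyl to hexyl, as pentyl would test, or keeps falling with a longer chain such as octyl. They also leave open how a hexyl chain ending in an amine would compare.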